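The source may report more compounds than this note shows. Statements on the series, on what has been measured and on what is new or still open speak of the compounds shown alone.

Series of acylhydrazones built on the shared core of compound 1 `O=C(CSc1nnc(-c2ccncc2)o1)N/N=C/c1cccc(F)c1`, read in a functional assay on MCF7 cells (Homo sapiens) for cytotoxicity, read by MTT assay, with a stated time of 48 h; on this read-out higher numbers stand for weaker inhibition and lower numbers for stronger inhibition: compound 1 gives 24900 nM. Compound 2 `O=C(CSc1nnc(-c2ccncc2)o1)N/N=C/c1ccccc1O` gives 4750 nM, the lower of the two numbers; the step of a 5.2-fold lower number from compound 1 to compound 2 (0.72 log units; beyond the scatter) is the only one measured so far and turns on the aryl group alone. Compound 3 `O=C(CSc1nnc(-c2ccncc2)o1)N/N=C/c1cc(Cl)cc(Cl)c1O` differs from compound 2 by 3,5-dichloro-2-hydroxyphenyl in place of 2-hydroxyphenyl on a carbon with a double bond to nitrogen. Among the measured compounds shown here, no measured step adds chlorine to that ring, so the expectation rests on compound 2 alone, with wide bounds. Compound 3 is estimated at 3500 nM, range 900 nM to 14000 nM. The step of a 1.4-fold lower number from compound 2 to compound 3 (0.13 log units; within the scatter) is expected to fall within the scatter.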

Compound 3, half-maximal inhibitory concentration: 5920 nM
Beside the measured number, compound 3's estimate is 1.7-fold (0.23 log units) below it; the measured number falls inside the stated range.
By their numbers in this assay, from the lowest: compounds 2 and 3 (each within the scatter of the next); then compound 1.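

On a carbon with a double bond to nitrogen, 3,5-dichloro-2-hydroxyphenyl in place of 2-hydroxyphenyl gives a 1.2-fold higher number from compound 2 to compound 3 (0.10 log units; within the scatter) in this assay, so this position accepts the two chlorine atoms with no change that can be told from scatter. The same group in place of 3-fluorophenyl gives a 4.2-fold lower number from compound 1 to compound 3 (0.62 log units; beyond the scatter) and thus joins compound 2 apart from compound 1. No available measurement bears on the reason for this result.

Going by these compounds, whether the hydroxy group alone separates compounds 2 and 3 from compound 1 remains open, since the aryl rings differ in more than that group. Also open, on these data alone, is how this position responds to an amine or a carboxylic acid on the aryl ring.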